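The compounds below may be only part of what the source reports. "The series", "measured", "known", "first", "only" and "open" are said of these compounds alone.

The shared core, seen in compound 1 `CC(C)n1ncc2c(C(=O)NCc3cn(-c4cccc(F)c4)nn3)cccc21`, is tested in a functional assay on MCF7 cells (Homo sapiens) for inhibition, read by MTT assay, with a stated time of 72 h; on this read-out lower numbers stand for stronger inhibition and higher numbers for weaker inhibition. In this assay compound 1 gives > 40000 nM, which is a limit of the assay and not a number. Compound 2 `CC(C)n1ncc2c(C(=O)NCc3cn(-c4ccc(C(F)(F)F)cc4)nn3)cccc21` differs from compound 1 by a 4-(trifluoromethyl)phenyl in place of 3-fluorophenyl on an aromatic nitrogen, and a step that the two limits leave unreadable from compound 1 to compound 2. In this assay compound 2 gives > 40000 nM, again a limit and not a number. Compound 2 therefore stands at the limit of > 40000 nM in this assay, at which 2 of the 2 values shown sit, and the values shown give no number for it. Compound 3 `CC(C)n1ncc2c(C(=O)NCc3cn(Cc4ccc(C#N)cc4)nn3)cccc21` has not yet been measured. It differs from compound 2 in one place: 4-cyanobenzyl in place of 4-(trifluoromethyl)phenyl on an aromatic nitrogen. Within the data shown here, the only measured step, from compound 1 to compound 2, cannot be read in size, so it gives no direction for the change to compound 3, and nothing measured here points to a gain in inhibition. Compound 3 is therefore expected to sit at the same limit, with an estimate of 40000 nM, between 10000 nM and 100000 nM. The expected step of a number no higher from compound 2 to compound 3 (the limit leaves the size open) is thus none beyond the scatter.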

Compound 3, half-maximal inhibitory concentration: > 40000 nM
Compound 3 was reported as a limit; the forecaster's own chance of this, stated with the estimate: 75%; the middle value lies on the limit itself.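

Compound 1, compound 2 and compound 3 all sit at a limit of the assay and not at a number, so the steps among them cannot be read in size: the limit of > 40000 nM in this assay, at which 3 of the 3 values shown sit. The compounds shown leave open how 3-fluorophenyl, 4-(trifluoromethyl)phenyl and 4-cyanobenzyl rank against one another in this assay.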